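The source may hold more compounds than are shown below. What is called first, only, known or untested is meant among the compounds shown, and "the series" means these compounds.

Measured so far in a functional assay on MCF7 cells (Homo sapiens) for cytotoxicity, read by MTT assay; a lower number here means a stronger inhibitor, a higher number a weaker inhibitor:
compound 1, `COCOc1cc(C#Cc2cc(OC)c(OC)c(OC)c2)ccc1OC`, gives 25600 nM.
compound 2, `COCOc1cc(/C=C\c2cc(OC)c(OC)c(OC)c2)ccc1OC`, gives 269 nM.
compound 3, `COc1ccc(C#Cc2cc(OC)c(OC)c(OC)c2)cc1NC(=O)OC(C)(C)C`, gives > 30000 nM, which is a limit of the assay and not a number.

Compound 1 and compound 2 carry the same two substituted rings, one of them bearing a methoxymethoxy group; how their two cores differ is not broken down here. In this assay compound 2 gives the lower of the two numbers, and the gap to compound 1 lies well beyond the usual scatter.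

From compound 1 to compound 3 one group is exchanged: (tert-butoxycarbonyl)amino in place of methoxymethoxy on an aromatic carbon. This gave an at least 1.1-fold higher number from compound 1 to compound 3 (0.06 log units; that floor lies within the scatter). The true size of that step is hidden, since compound 3 sits at the limit of > 30000 nM in this assay, at which 1 of the 3 values shown sits.

Compound 4, `COc1ccc(/C=C\c2cc(OC)c(OC)c(OC)c2)cc1NC(=O)OC(C)(C)C`, has not yet been measured. It stands to compound 2 as compound 3 stands to compound 1: (tert-butoxycarbonyl)amino in place of methoxymethoxy on an aromatic carbon. The surroundings of the exchanged group are described in the same words for both pairs, so this is the same change made on the second core.

For compound 4 a weakening relative to compound 2 is expected, a step of about a 9.3-fold higher number from compound 2 to compound 4 (0.97 log units; beyond the scatter), resting on compound 1 and compound 3 having shown an at least 1.1-fold higher number from compound 1 to compound 3 (0.06 log units; that floor lies within the scatter) while only a floor of that step could be read. The estimate for compound 4 in this assay is therefore 2500 nM, with a plausible range from 400 nM to 15000 nM.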

Compound 4, half-maximal inhibitory concentration: 3850 nM
Compound 4: middle estimate off by 1.5-fold (0.19 log units), on the low side; the measured number falls inside the stated range.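

In this assay, exchanging methoxymethoxy for (tert-butoxycarbonyl)amino on an aromatic carbon gives a 14-fold higher number from compound 2 to compound 4 (1.16 log units; beyond the scatter), so on this core the change clearly weakens the compound. On the other core, compound 3 gives > 30000 nM, which is a limit of the assay and not a number, so the full size of the step there cannot be read. The result therefore does not show whether the change costs the same on both cores, and it cannot be said to carry over with a known size, only that the readable floor and the new step do not contradict each other: the same change on two cores in this assay, an at least 1.1-fold higher number (0.06 log units; that floor lies within the scatter) from compound 1 to compound 3 and a 14-fold higher number (1.16 log units; beyond the scatter) from compound 2 to compound 4; the limit leaves it open whether they differ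

Among the compounds shown, only methoxymethoxy and (tert-butoxycarbonyl)amino appear at this place, so it remains open how a free amine, a hydroxyl group or an acetamide would behave there. Going by these compounds, it also remains open whether a group that gives a value inside the measurable range on both cores would show a step of similar size on each, which is what a real comparison between the two cores would need.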